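This account rests on a few compounds, and the source may have more. Where it says the series, first, only, none or still open, it means among the compounds named here.

Working notes on the series. Compound 1 `O=C1COc2ccc(-c3cnc(Cl)c(NS(=O)(=O)c4ccc(F)cc4)c3)cc2N1C1CCCCC1` carries a cyclohexyl on the amide-type nitrogen of the ring; in a functional assay on HCT-116 cells (Homo sapiens) for antiproliferative activity, read by MTT assay, with a stated time of 72 h (a higher number here means a weaker inhibitor, a lower number a stronger inhibitor), compound 1 returns only a limit, > 40000 nM. Compound 2 `Cc1ccc(N2C(=O)COc3ccc(-c4cnc(Cl)c(NS(=O)(=O)c5ccc(F)cc5)c4)cc32)cc1` carries a 4-methylphenyl at the same position and in this assay compound 2 gives 34300 nM, the only number shown. The measured step of an at least 1.1-fold lower number from compound 1 to compound 2 (0.06 log units; that floor lies within the scatter) is therefore set against a floor, as the evidence the limit of > 40000 nM in this assay, at which 1 of the 2 values shown sits, makes clear.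

Compound 3 `O=C1COc2ccc(-c3cnc(Cl)c(NS(=O)(=O)c4ccc(F)cc4)c3)cc2N1C1CC1` follows from compound 2 by cyclopropyl in place of 4-methylphenyl on an amide-type nitrogen in a ring. Among the measured compounds shown here, the cyclohexyl-to-4-methylphenyl step is the only one bearing on a change at this position, and it gives no direction beyond the scatter. The expected step of a 1.2-fold higher number from compound 2 to compound 3 (0.07 log units; within the scatter) is small, with a real chance that only a limit is returned. For compound 3 the estimate in this assay is 40000 nM, within 15000 nM to 100000 nM.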

Compound 3, half-maximal inhibitory concentration: 12400 nM
Compound 3: the middle estimate sits 3.2-fold (0.51 log units) above what was measured; measured number below the stated range.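

In this assay this position now shows a change beyond the scatter: cyclopropyl in place of 4-methylphenyl gives a 2.8-fold lower number from compound 2 to compound 3 (0.44 log units; beyond the scatter). Set against the cyclohexyl of compound 1, the same group gives an at least 3.2-fold lower number from compound 1 to compound 3 (0.50 log units; beyond the scatter), so compound 3 has the lowest number of the three, with both of its steps beyond the scatter. The second of these steps is a floor and not a full size: the limit of > 40000 nM in this assay, at which 1 of the 3 values shown sits.

The three compounds do not show whether the number follows the size of the group, as cyclohexyl and 4-methylphenyl remain unseparated beyond the scatter. From the compounds shown here alone, whether a methyl, a cyclobutyl or a short chain ending in an amine on this nitrogen would lower the number further stays open.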